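Adding a second chloro group to compound 2

The compounds below may be only part of what the source reports. "The series", "measured", "known", "first", "only" and "open" are said of these compounds alone.

In an assay on HEK293 cells for displacement of a labelled ligand from Neuronal acetylcholine receptor; alpha3/beta4 (Homo sapiens) (on this read-out higher numbers stand for weaker inhibition and lower numbers for stronger inhibition), three compounds have been measured:

compound 1, `Clc1ccc(Nc2cncc(N3CC4CC(C3)N4)c2)cc1`: 1.2 nM
compound 2, `Clc1cccc(Nc2ccc(N3CC4CC(C3)N4)cn2)c1`: 4.8 nM
compound 3, `c1ccc(Nc2cncc(N3CC4CC(C3)N4)c2)cc1`: 0.799 nM

Compound 1 and compound 3 differ by one change, (chloro in place of hydrogen on an aromatic carbon), and this step gave a 1.5-fold higher number from compound 3 to compound 1 (0.18 log units; within the scatter). Compound 2 carries a different core; the difference between its core and the core of compound 3 is not broken down here, and the two values show compound 2 with the highest number of the three.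

Compound 4, `Clc1ccc(Nc2ccc(N3CC4CC(C3)N4)cn2)cc1Cl`, has not yet been measured. It differs from compound 2 by chloro in place of hydrogen on an aromatic carbon. This is the same kind of change as that from compound 3 to compound 1, though not the same: in compound 4 the entering chloro group also sits ortho to a chloro group, which is not so in compound 1.

Because the earlier step was a 1.5-fold higher number from compound 3 to compound 1 (0.18 log units; within the scatter), the step from compound 2 to compound 4 in this assay is expected to be of similar size, a 1.5-fold higher number from compound 2 to compound 4 (0.16 log units; within the scatter). Compound 4 is therefore estimated at 7 nM, with a likely range from 3 nM to 16 nM.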

Compound 4, inhibition constant: 40.9 nM
The estimate for compound 4 lay 5.8-fold (0.77 log units) below the measured number; measured number above the stated range.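

In this assay, chloro in place of hydrogen on an aromatic carbon gave an 8.5-fold higher number from compound 2 to compound 4 (0.93 log units; beyond the scatter), which means weaker inhibition on the core of compound 2. Set beside the earlier step, the change did not carry over in size from one core to the other: the same change on two cores in this assay, a 1.5-fold higher number (0.18 log units; within the scatter) from compound 3 to compound 1 and an 8.5-fold higher number (0.93 log units; beyond the scatter) from compound 2 to compound 4, 5.7-fold (0.75 log units) apart, beyond the scatter of two such steps. This does not show that the core alone sets the size of the step, as the two pairs also differ in the surroundings of the entering chloro group, which in compound 4 sits ortho to a chloro group and in compound 1 does not.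

The compounds shown leave open whether the larger step belongs to chloro itself or would also appear with a fluoro or a methoxy group entering at the same place on compound 2. They also leave open whether a second chloro group on the core of compound 1 would give a step like that from compound 2.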